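Sulfonate aryl swap in the nitrobenzamide branch

The compounds below may be only part of what the source reports. "The series", "measured", "known", "first", "only" and "open" are said of these compounds alone.

Going by the values given here, compound 2 `O=C(c1ccc([N+](=O)[O-])cc1)N1CCC(n2cncc2-c2ccc(OS(=O)(=O)c3cccc4cnccc34)cc2)CC1` gives 8.29 nM in an assay on THP-1 cells for antagonist activity at P2X purinoceptor 7 (Homo sapiens), read by ELISA, with a stated time of 30 min (a higher number here means a weaker inhibitor, a lower number a stronger inhibitor), the lowest of the three numbers so far. Compound 1 `COc1ccc(C(=O)N2CCC(n3cncc3-c3ccc(OS(=O)(=O)c4cccc5cnccc45)cc3)CC2)cc1` gives 64 nM and compound 3 `CC(C)c1ccc(C(=O)N2CCC(n3cncc3-c3ccc(OS(=O)(=O)c4cccc5cnccc45)cc3)CC2)cc1` gives 37 nM. The measured steps, a 7.7-fold lower number from compound 1 to compound 2 (0.89 log units; beyond the scatter) and a 4.5-fold higher number from compound 2 to compound 3 (0.65 log units; beyond the scatter), both sit on the benzamide ring, where the nitro group stands out; a 1.7-fold lower number from compound 1 to compound 3 (0.24 log units; within the scatter) is within the scatter. Compound 4 `CNC(=O)c1cccc(S(=O)(=O)Oc2ccc(-c3cncn3C3CCN(C(=O)c4ccc([N+](=O)[O-])cc4)CC3)cc2)c1` keeps that nitro group and changes the other end: 3-(methylcarbamoyl)phenyl in place of isoquinolin-5-yl on a sulfonyl sulfur. Among the compounds with values here, no measured step touches the group on the sulfonyl sulfur, so the three steps above give no direct guide. The expectation for compound 4 is therefore only a small step, a 2.4-fold higher number from compound 2 to compound 4 (0.38 log units; beyond the scatter), with wide uncertainty. Compound 4 is estimated at 20 nM, range 4 nM to 100 nM.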

Compound 4, half-maximal inhibitory concentration: 26 nM
Beside the measured number, compound 4's estimate is 1.3-fold (0.11 log units) below it; measured number inside the range.
By their numbers in this assay, from the lowest: compound 2; then compounds 4, 3 and 1 (each within the scatter of the next, the first and the last beyond it).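

With the nitrobenzamide held fixed, the group on the sulfonyl sulfur also moves the number in this assay: 3-(methylcarbamoyl)phenyl in place of isoquinolin-5-yl gives a 3.1-fold higher number from compound 2 to compound 4 (0.50 log units; beyond the scatter). The step is modest, so this position accepts a group with one aromatic ring of carbon only and a hydrogen-bond donor, at an equal heavy-atom count, at some cost. Nothing available explains the step.

From the compounds shown here alone, whether the same swap gives a step of similar size in the methoxy or isopropyl benzamides remains open. So does the effect of a carboxylic acid or an amine in place of the methylcarbamoyl group.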